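Methyl to trifluoromethyl on the aryl ring: working notes

A few compounds are considered here, and "the series" means these few. Any claim that something is new, unique, unknown or untested is made for them only; others in the source may bear on it.

Compound 1 `CCC1=C(O)c2c(oc(-c3ccc(C)cc3)cc2=O)C(CC)(CC)C1=O`, compound 2 `CCC1=C(O)c2c(oc(-c3ccc(C(F)(F)F)cc3)cc2=O)C(CC)(CC)C1=O` and compound 3 `CCC1=C(O)c2c(oc(-c3cccc(C)c3)cc2=O)C(CC)(CC)C1=O` have been measured in a functional assay on KB cells (Homo sapiens) for antiproliferative activity, read by sulforhodamine B assay, with a stated time of 3 days; on this read-out lower numbers stand for an effect already at smaller amounts and higher numbers for an effect only at larger amounts of compound; compound 4 `CCC1=C(O)c2c(oc(-c3cccc(C(F)(F)F)c3)cc2=O)C(CC)(CC)C1=O` has not. In this assay compound 1 gives 39.2 uM, compound 2 gives 35.7 uM and compound 3 gives 49.7 uM. All three numbers lie within the scatter of one another, so no order among them is claimed.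

Compound 2 differs from compound 1 by trifluoromethyl in place of methyl on an aromatic carbon, and the step is a 1.1-fold lower number from compound 1 to compound 2 (0.04 log units; within the scatter). Compound 3 differs from compound 1 in the core by 3-methylphenyl in place of 4-methylphenyl on an aromatic carbon, and that step is a 1.3-fold higher number from compound 1 to compound 3 (0.10 log units; within the scatter).

Compound 4 stands to compound 3 as compound 2 stands to compound 1: the change is trifluoromethyl in place of methyl on an aromatic carbon. It is the same kind of change, not the same one: in compound 2 the entering group sits para to a large group, whereas in compound 4 it sits meta to a large group. Among the measured compounds the change has been made once, and there it shifted the read-out by an amount within the scatter. The step expected for compound 4 is a 1.1-fold lower number from compound 3 to compound 4 (0.04 log units; within the scatter). This expectation rests on the size of a 1.1-fold lower number from compound 1 to compound 2 (0.04 log units; within the scatter) and on the value of compound 3, 49.7 uM. Compound 4 is expected to give 45 uM in this assay, with a likely range from 22 uM to 90 uM. Among the measured compounds shown here, only a single pair shows the change. The range is therefore set wide.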

Compound 4, concentration for half-maximal effect: 35.7 uM
Beside the measured number, compound 4's estimate is 1.3-fold (0.10 log units) above it, and the stated range covers the measured number.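

In this assay the new step is a 1.4-fold lower number from compound 3 to compound 4 (0.14 log units; within the scatter), so trifluoromethyl in place of methyl again leaves the read-out within the scatter, here with the entering group meta to a large group. Set beside the earlier step, the change carries from the core of compound 1 to the core of compound 3 with no difference that these data can separate: the same change on two cores in this assay, a 1.1-fold lower number (0.04 log units; within the scatter) from compound 1 to compound 2 and a 1.4-fold lower number (0.14 log units; within the scatter) from compound 3 to compound 4, 1.3-fold (0.10 log units) apart, within the scatter of two such steps. Among the compounds shown here, this shows only that the change gave no readable shift on either of these two cores in this assay; it does not show that the two steps are equal, that a small real shift is absent, or that the change would stay this small on any further core.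

The compounds shown vary the aryl ring only through methyl and trifluoromethyl, so it stays open whether an amine, a carboxylic acid or a longer chain in the same place would move the read-out beyond the scatter. Also open, on these data alone, is whether replacing the ethyl groups on the shared core with a longer chain would alter the size of this step, and whether the pattern holds in any other cell line.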